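Extending the Methyl Substituent in a Sulfonamide Series

This account rests on a few compounds, and the source may have more. Where it says the series, first, only, none or still open, it means among the compounds named here.

Compound 1 `COc1ccc(NS(=O)(=O)c2ccc(N3CCNC3=O)cc2)cc1`: 800 nM
Compound 2 `O=C1NCCN1c1ccc(S(=O)(=O)Nc2ccc(OC(F)F)cc2)cc1`: 650 nM
Compound 3 `Cc1ccc(NS(=O)(=O)c2ccc(N3CCNC3=O)cc2)cc1`: 480 nM

In a functional assay on HT-29 cells (Homo sapiens) for antiproliferative activity, read by sulforhodamine B assay, with a stated time of 48 h (on this read-out higher numbers stand for weaker inhibition and lower numbers for stronger inhibition), compound 3 is separated from compound 1 by a 1.7-fold lower number from compound 1 to compound 3 (0.22 log units; within the scatter) and from compound 2 by a 1.4-fold lower number from compound 2 to compound 3 (0.13 log units; within the scatter); both steps sit within the scatter, so the three compounds are not distinguished here. Compound 4 `CCCCc1ccc(NS(=O)(=O)c2ccc(N3CCNC3=O)cc2)cc1` differs from compound 3 by propyl in place of hydrogen on a saturated chain carbon bound to an aromatic carbon. Within the data shown here, no measured step changes a saturated chain on this ring; the nearest comparisons, a 1.7-fold lower number from compound 1 to compound 3 (0.22 log units; within the scatter) and a 1.4-fold lower number from compound 2 to compound 3 (0.13 log units; within the scatter), swap small groups on the same aromatic carbon and move the number very little. On that basis no step beyond the scatter is expected in this assay, and compound 4 is estimated at 450 nM, between 150 nM and 1400 nM. The expected step is a 1.1-fold lower number from compound 3 to compound 4 (0.03 log units; within the scatter).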

Compound 4, half-maximal inhibitory concentration: 610 nM
Compound 4: middle estimate off by 1.4-fold (0.13 log units), on the low side; measured number inside the range.
By their numbers in this assay, from the lowest: compounds 3, 4, 2 and 1 (each within the scatter of the next).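

In this assay, butyl is the only chain longer than methyl on this aromatic carbon among these compounds, and the methyl to butyl change stays within the scatter (a 1.3-fold higher number from compound 3 to compound 4 (0.10 log units; within the scatter)). Butyl is likewise not distinguished from the oxygen-linked groups on the same carbon (a 1.1-fold lower number from compound 2 to compound 4 (0.03 log units; within the scatter); a 1.3-fold lower number from compound 1 to compound 4 (0.12 log units; within the scatter)). This position therefore accepts the added propyl without a measurable change in the number, and no supporting measurement bears on this result. On these data alone, whether a longer chain, an amine or a carboxylic acid on this aromatic carbon would move the number beyond the scatter remains open.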